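Antiproliferative series: aryl amine change at the assay limit

The compounds below may be only part of what the source reports. "The series", "measured", "known", "first", "only" and "open" are said of these compounds alone.

Measured compounds in a functional assay on A549 cells (Homo sapiens) for antiproliferative activity, read by MTT assay, with a stated time of 48 h; on this read-out lower numbers stand for stronger inhibition and higher numbers for weaker inhibition:
- compound 1, `CCOC(=O)CN(Cc1ccccc1)c1nc(NCc2ccccc2)ncc1[N+](=O)[O-]`; compound 1 gives only a limit, > 100000 nM
- compound 2, `CCOC(=O)CNc1ncc([N+](=O)[O-])c(N(CC(=O)OCC)Cc2ccccc2)n1`; compound 2 gives only a limit, > 100000 nM
- compound 3, `CCOC(=O)CN(Cc1ccccc1)c1nc(Nc2ccc(Cl)cc2)ncc1[N+](=O)[O-]`; compound 3 gives only a limit, > 100000 nM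

Compound 3 thus stands at the same limit as the other two values in this assay; no ordering among the three is possible. The steps a step that the two limits leave unreadable from compound 1 to compound 2, a step that the two limits leave unreadable from compound 1 to compound 3 and a step that the two limits leave unreadable from compound 2 to compound 3 are each left unreadable, since every value shown sits at the limit of > 100000 nM in this assay, at which 3 of the 3 values shown sit.

Compound 4, `CCOC(=O)CN(Cc1ccccc1)c1nc(Nc2cccc(OC)c2)ncc1[N+](=O)[O-]`, differs from compound 3 by 3-methoxyphenyl in place of 4-chlorophenyl on a nitrogen on an aromatic ring. For the measured compounds named here, none of the measured steps reads out, so no direction or size can be drawn from them; the only fact in hand is that three different substituents on the same nitrogen and the neighbouring chain all fail to give a number in this assay.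

Compound 4 is therefore expected to remain at or near the limit, with an estimate of 150000 nM and a range from 40000 nM to 600000 nM. The expected step is a step that the limit leaves unreadable from compound 3 to compound 4, meaning no readable change is anticipated.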

Compound 4, half-maximal inhibitory concentration: > 100000 nM
Compound 4: only a limit was reported; the forecaster's own chance of this, stated with the estimate: 85%; the middle value is on the limit's open side.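

In this assay compound 4 gives only a limit, > 100000 nM. No new step can be read between compound 4 and compound 1, compound 2 or compound 3, since all four sit at one limit: the limit of > 100000 nM in this assay, at which 4 of the 4 values shown sit.

The compounds shown leave open whether any change on the shared core gives a readable value in this assay.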